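This account rests on a few compounds, and the source may have more. Where it says the series, first, only, none or still open, it means among the compounds named here.

The measured compounds:
compound 1 `NC(=S)N/N=C/c1ccc2ccccc2n1` gives > 100000 nM, a limit of the assay
compound 2 `NC(=S)N/N=C/c1cc2ccccc2s1` gives > 100000 nM, a limit of the assay
compound 3 `CN(C)C(=S)N/N=C/c1cnc2ccccc2n1` gives 90 nM

All three were tested in a functional assay on HL-60 cells (Homo sapiens) for antiproliferative activity, read by sulforhodamine B assay, with a stated time of 72 h; on this read-out higher numbers stand for weaker inhibition and lower numbers for stronger inhibition. For compound 1 the result is a limit of the assay and not a number. Compound 2 also gives only a limit. Compound 3 alone gives an actual number. Going by the values given here, compound 1 thus stands at the limit of > 100000 nM in this assay, at which 2 of the 3 values shown sit, and the single numerical value belongs to a compound that differs from it in more than one place, so no measured step from compound 1 to any other compound exists here, and no single change can be weighed on its own.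

The new compound is compound 4 `COc1ccccc1NC(=S)N/N=C/c1ccc2ccccc2n1`. It differs from compound 1 by one change: 2-methoxyphenyl in place of hydrogen on an amide-type nitrogen. Among the compounds with values here, with no measured step to go by, the size of the effect in this assay is open. Compound 1 sits at a limit, so a step can only go toward stronger inhibition or stay at the limit. Compound 4 is estimated at 8000 nM, in the range 500 nM to 100000 nM. This estimate means an expected step of an at least 12-fold lower number from compound 1 to compound 4 (1.09 log units; beyond the scatter) toward stronger inhibition, held with low confidence.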

Compound 4, half-maximal inhibitory concentration: 91700 nM
Compound 4: middle estimate off by 11-fold (1.06 log units), on the low side; low and high end bracket the measured number.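

In this assay compound 1 gives > 100000 nM, which is a limit of the assay and not a number. Compound 4, which carries 2-methoxyphenyl in place of hydrogen on the amide-type nitrogen bonded to the thiocarbonyl carbon, gives a true number at 91700 nM, so this position now has its first measured step, an at least 1.0-fold lower number from compound 1 to compound 4 (0.03 log units; that floor lies within the scatter), and the large aromatic group does not push the value out of the measurable range. The real size of this step cannot be read, and it may be anything from nothing beyond the usual scatter to a larger gain, because the starting point is only a limit: the limit of > 100000 nM in this assay, at which 2 of the 4 values shown sit.

The compounds shown leave open how much of the change belongs to the six-membered aromatic ring and how much to its methoxy group, and how a plain phenyl ring, a methyl group or a longer alkyl chain on this nitrogen would read. They also leave open whether an amine or a carboxylic acid on the 2-methoxyphenyl ring would move the number in either direction.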